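A few compounds are considered here, and "the series" means these few. Any claim that something is new, unique, unknown or untested is made for them only; others in the source may bear on it.

Going by the values given here, in a physicochemical assay for lipophilicity, read by HPLC (on this read-out lower numbers stand for lower lipophilicity and higher numbers for higher lipophilicity), compound 2 `Cc1ccsc1C(=CCCN(C)C(CCO)C(=O)NCc1ccc(F)cc1)c1sccc1C` gives 5.87, the middle of the three numbers so far. Compound 3 `Cc1ccsc1C(=CCCN(C)C(CO)C(=O)NCc1ccc(F)cc1)c1sccc1C` sits higher at 6.45, and compound 1 `Cc1ccsc1C(=CCCN(C)C(CCO)C(=O)N1CCOCC1)c1sccc1C` sits lower at 4.75.

Compound 4 `Cc1ccc(CNC(=O)C(CCO)N(C)CCC=C(c2sccc2C)c2sccc2C)cc1` has not been measured. Its structure departs from that of compound 2 at a single place: methyl in place of fluoro on an aromatic carbon. In words, this is methyl in place of fluoro on an aromatic carbon, para to a large group.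

Two measured steps offer some guidance, though neither tests this swap. The large step of a number 1.12 log units higher from compound 1 to compound 2 (beyond the scatter) goes with (4-fluorobenzyl)amino in place of morpholin-4-yl on a carbonyl carbon. The modest step of a number 0.58 log units higher from compound 2 to compound 3 (beyond the scatter) goes with hydroxy in place of hydroxymethyl on a saturated chain carbon. They serve only as a rough ruler, and a small upward move, smaller than both, is expected in this assay.

The estimated move is a number 0.33 log units higher from compound 2 to compound 4 (beyond the scatter). For compound 4, the expected value is 6.2, within an estimated range from 5.8 to 6.6.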

Compound 4, partition coefficient: 6.2
Beside the measured number, compound 4's estimate shows no gap at the digits printed; low and high end bracket the measured number.
By their numbers in this assay, from the lowest: compound 1; then compound 2; then compounds 4 and 3 (each within the scatter of the next).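

Until now, the ring carrying the fluoro group had only been seen as part of a whole replacement for morpholin-4-yl, so nothing showed whether this single aromatic carbon, para to a large group, matters in this assay. Methyl in place of fluoro gives a number 0.33 log units higher from compound 2 to compound 4 (beyond the scatter), so exchanging one heavy atom for another, with no hydrogen-bond donor or acceptor entering or leaving, moves the read-out beyond the scatter. The replacement of morpholin-4-yl also remains large with the methyl-bearing group, at a number 1.45 log units higher from compound 1 to compound 4 (beyond the scatter), but no measurement here explains either step.

Going by these compounds, with only fluoro and methyl to go on, it remains open where a chloro, methoxy or nitrile group on this same carbon would fall. On these data alone, it is also open whether the same swap would give a similar step in compound 3, whose side chain differs.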